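A Hydroxy Group Added to Compound 1

The source may report more compounds than this note shows. Statements on the series, on what has been measured and on what is new or still open speak of the compounds shown alone.

In a functional assay on the whole organism with Rattus norvegicus as the target (on this read-out lower numbers stand for an effect already at smaller amounts and higher numbers for an effect only at larger amounts of compound), compound 1 (`CCOC(=O)C(=O)Nc1nc(-c2cc(OC)cc(OC)c2)cs1`) gives about 10 mg/kg, the higher of the two numbers, while compound 2 (`COc1cc(OC)cc(-c2csc(NC(=O)C(=O)O)n2)c1`) gives about 1 mg/kg. Compound 3 (`CCOC(=O)C(=O)Nc1nc(-c2cc(OC)c(O)c(OC)c2)cs1`) differs from compound 1 by hydroxy in place of hydrogen on an aromatic carbon, ortho to two methoxy groups and para to a large group. Within the data shown here, the only measured step, a 10-fold lower number from compound 1 to compound 2 (1.00 log units; beyond the scatter), concerns the ethyl group rather than this aromatic carbon, so it offers no direct guide. No change beyond the scatter is therefore expected, with the estimated step being a 1.3-fold lower number from compound 1 to compound 3 (0.10 log units; within the scatter). Compound 3 is estimated at 8 mg/kg, with an expected range of 2 mg/kg to 30 mg/kg.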

Compound 3, dose for half-maximal effect: about 10 mg/kg
The estimate for compound 3 lay 1.3-fold (0.10 log units) below the measured number; measured number inside the range.
By their numbers in this assay, from the lowest: compound 2; then compounds 1 and 3 (each within the scatter of the next).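

In this assay hydroxy in place of hydrogen on this aromatic carbon brings no change at the digits printed from compound 1 to compound 3 (within the scatter) and so shows that this position, which the earlier pair left untouched, can carry the hydroxy with the number held. The earlier step concerned only the ethyl group, and this change does not match it in size. Nothing available accounts for this result. On these data alone, whether an amine or a longer alkoxy chain on this aromatic carbon would also hold the number stays open. Also open, as far as these compounds go, is how hydroxy here would read with hydrogen in place of ethyl.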